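A few compounds are considered here, and "the series" means these few. Any claim that something is new, unique, unknown or untested is made for them only; others in the source may bear on it.

Measured compounds in a functional assay on HCT-116 cells (Homo sapiens) for antiproliferative activity, read by CCK-8 assay, with a stated time of 72 h, tested at 8 uM; a higher number here means a stronger effect of the compound at the concentration tested, a lower number a weaker effect:

Compound 1, `CC(C)n1cnc2c(Nc3cccc(Cl)c3)nc(NCOCc3ccc(C(=O)Nc4ccccc4N)cc3)nc21`, gives 63.4%.
Compound 2, `CCCCn1cnc2c(Nc3ccccc3)nc(NCOCc3ccc(/C=C/C(=O)Nc4ccccc4N)cc3)nc21`, gives 51.9%.
Compound 3, `CC(C)n1cnc2c(Nc3ccccc3)nc(NCOCc3ccc(C(=O)Nc4ccccc4N)cc3)nc21`, gives 18.8%.

Compound 1 has the highest of the three numbers in this assay. Compound 2 sits nearest to it, and compound 3 furthest. Only one pair among these differs in a single place: the change of a number 44.6 percentage points lower from compound 1 to compound 3 (beyond the scatter), where hydrogen replaces chloro on an aromatic carbon. Compound 2 differs from compound 1 in more than one place, so its value can only be set beside that of compound 1 without being tied to any one change.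

The unmeasured compound 4, `Nc1ccccc1NC(=O)c1ccc(COCNc2nc(Nc3cccc(Cl)c3)c3ncn(C4CCCC4)c3n2)cc1`, keeps the chloro of compound 1 and differs from it in one place: cyclopentyl in place of isopropyl on an aromatic nitrogen. Among the measured compounds shown here, no measured step touches this position, so the large step from compound 1 to compound 3 gives no guide to it, and nothing here speaks to changing the group on the aromatic nitrogen. For the measured compounds named here, with no bearing step, the expectation is that compound 4 stays near compound 1, and the estimated step of a number 3.4 percentage points lower from compound 1 to compound 4 (within the scatter) is one within the scatter. The estimate for compound 4 in this assay is 60%, with a range from 40% to 78%.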

Compound 4, a percentage reported as inhibition, at one concentration (the size of the read-out at that concentration, not a potency): 40.6%
Beside the measured number, compound 4's estimate is 19.4 percentage points above it; measured number inside the range.
By their numbers in this assay, from the lowest: compound 3; then compound 4; then compound 2; then compound 1.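

In this assay, the group on the aromatic nitrogen proves to be a position that matters: swapping isopropyl for cyclopentyl gives a number 22.8 percentage points lower from compound 1 to compound 4 (beyond the scatter). Among the compounds shown here, the earlier step, a number 44.6 percentage points lower from compound 1 to compound 3 (beyond the scatter), came from a change on an aromatic carbon, so the chloro is not the only place in compound 1 where a single change moves this read-out beyond the scatter; at this nitrogen, the larger group that brings in a five-membered ring of carbon only goes with the lower number. No supporting data are available to explain why this swap lowers the read-out.

Still open, from the compounds shown here alone, is whether the ring itself or simply the larger group goes with the drop, and a cyclobutyl ring or an open chain such as isopentyl on the same nitrogen of compound 1 would help separate the two, while a methyl or ethyl group would show what happens with a smaller one. The butyl group of compound 2 cannot settle this, as that compound differs from compound 1 in more than one place.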